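The source may report more compounds than this note shows. Statements on the series, on what has been measured and on what is new or still open speak of the compounds shown alone.

Compound 1 `CCN(CC)c1cc2[nH]c(C3CCCCC3)nc2cc1NC(=O)OCC(F)(F)F` gives in an ADME assay on Vero cells (Chlorocebus sabaeus) for cytotoxicity, read by resazurin assay, with a stated time of 3 days (on this read-out lower numbers stand for stronger inhibition and higher numbers for weaker inhibition), only a limit, > 100 ug/mL.
Compound 2 `CCCNC(=O)Nc1cc2nc(C3CCCCC3)[nH]c2cc1N(CC)CC` gives in this assay only a limit, > 100 ug/mL.
Compound 3 `CCCC(C)OC(=O)Nc1cc2nc(C3CCCCC3)[nH]c2cc1N(CC)CC` gives in this assay only a limit, > 100 ug/mL.

All three measured compounds share one core and differ only in the group on the carbonyl carbon attached to the amide-type nitrogen. None of them reaches a measurable number: every value sits at the limit of > 100 ug/mL in this assay, at which 3 of the 3 values shown sit. Compound 3 therefore stands at that limit, level with the other two as far as the numbers can tell. The three steps between the measured compounds, a step that the two limits leave unreadable from compound 1 to compound 2, a step that the two limits leave unreadable from compound 1 to compound 3 and a step that the two limits leave unreadable from compound 2 to compound 3, cannot be read in size or direction, since a limit on both ends hides any difference.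

Compound 4 `CCc1ccc(C(=O)Nc2cc3nc(C4CCCCC4)[nH]c3cc2N(CC)CC)cc1` is the next compound in this series. It differs from compound 3 as follows: 4-ethylphenyl in place of 1-methylbutoxy on a carbonyl carbon. Within the data shown here, no measured step covers a change of this kind, so nothing in the data points to a readable shift; what the data do show is that three different groups at this place all left the value at the limit.

The step from compound 3 to compound 4 is expected to be a number no higher from compound 3 to compound 4 (the limit leaves the size open), meaning no change beyond the scatter. Compound 4 is therefore estimated at 100 ug/mL, with a range from 40 ug/mL to 250 ug/mL, most likely reported again only as a limit.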

Compound 4, half-maximal inhibitory concentration: > 100 ug/mL
Compound 4 gave a limit, no number (the forecaster's own chance of this, stated with the estimate: 75%); the middle value lies on the limit itself.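

In this assay compound 4 gives only a limit, > 100 ug/mL. Its steps from compound 1, compound 2 and compound 3 cannot be read in size or direction, because all four values rest on the same limit: the limit of > 100 ug/mL in this assay, at which 4 of the 4 values shown sit. The compounds shown leave open whether the four groups on the carbonyl carbon differ in cytotoxicity at all.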